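Methylsulfonyl in Place of Chloro: Expecting Compound 4

This account rests on a few compounds, and the source may have more. Where it says the series, first, only, none or still open, it means among the compounds named here.

Three measured compounds share one core and differ in a single group. Among the measured compounds shown here, in a functional assay on MDA-MB-468 cells (Homo sapiens) for antiproliferative activity, read by MTT assay, with a stated time of 72 h (on this read-out higher numbers stand for weaker inhibition and lower numbers for stronger inhibition), compound 3 `O=C(Nc1ccc(Cl)c(-c2nnc3c(Cl)cccn23)c1)c1ccc(Cl)cc1Cl` gives 21600 nM, the only true number among the three. Compound 1 `O=C(Nc1ccc(Cl)c(-c2nnc3c(Cl)cccn23)c1)c1ccc(C(F)(F)F)cc1Cl` reaches only a limit, > 100000 nM. Compound 2 `O=C(Nc1ccc(Cl)c(-c2nnc3c(Cl)cccn23)c1)c1ccc(F)cc1Cl` likewise shows a limit, > 100000 nM. The steps of an at least 4.6-fold lower number from compound 1 to compound 3 (0.66 log units; beyond the scatter) and an at least 4.6-fold lower number from compound 2 to compound 3 (0.66 log units; beyond the scatter) are thus at least modest, whereas the step that the two limits leave unreadable from compound 1 to compound 2 cannot be read because both values sit at the limit of > 100000 nM in this assay, at which 2 of the 3 values shown sit. Compound 4 `CS(=O)(=O)c1ccc(C(=O)Nc2ccc(Cl)c(-c3nnc4c(Cl)cccn34)c2)c(Cl)c1` differs from compound 3 by methylsulfonyl in place of chloro on an aromatic carbon. For the measured compounds named here, no measured step covers a methylsulfonyl group, so the steps toward chloro are the only guide, and leaving chloro may undo part of that gain. Compound 4 is expected near 50000 nM, within 8000 nM to 100000 nM. The step of a 2.3-fold higher number from compound 3 to compound 4 (0.36 log units; beyond the scatter) is the estimated change.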

Compound 4, half-maximal inhibitory concentration: > 100000 nM
Compound 4 gave a limit, no number; the forecaster's own chance of this, stated with the estimate: 40%; middle value at least 2.0-fold (0.30 log units) from the limit.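

In this assay, methylsulfonyl in place of chloro gives an at least 4.6-fold higher number from compound 3 to compound 4 (0.66 log units; beyond the scatter), so a second kind of replacement for chloro at this position, one with hydrogen-bond acceptors, also loses the measurable activity. Among the four groups shown here, only chloro gives a true number, while trifluoromethyl, fluoro and methylsulfonyl all end at a limit. The steps among compounds 1, 2 and 4 cannot be read because all three sit at the same limit: the limit of > 100000 nM in this assay, at which 3 of the 4 values shown sit.

Going by these compounds, whether bromo, methyl or an amine at this position would give a true number, and whether any of them would give a lower number than compound 3, remains open.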